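Chloro substitution on an inactive chromenone thioether series

The source may report more compounds than this note shows. Statements on the series, on what has been measured and on what is new or still open speak of the compounds shown alone.

Compound 1, `Cc1nnc(SCc2cc(=O)c3cc(Cl)ccc3o2)o1`: > 25000 nM, a limit.
Compound 2, `Cc1nnc(SCc2cc(=O)c3ccccc3o2)o1`: > 25000 nM, a limit.
Compound 3, `Nc1nnc(SCc2cc(=O)c3ccccc3o2)s1`: > 25000 nM, a limit.

All three measured compounds were tested in a functional assay on MCF7 cells (Homo sapiens) for cytotoxicity, read by MTT assay, with a stated time of 72 h (on this read-out lower numbers stand for stronger inhibition and higher numbers for weaker inhibition), and each returned only a limit of the assay rather than a number, as the limit of > 25000 nM in this assay, at which 3 of the 3 values shown sit, states. The change from compound 2 to compound 1 is chloro in place of hydrogen on an aromatic carbon, and its step that the two limits leave unreadable from compound 2 to compound 1 cannot be read because both values are limits. The two cores differ by 5-amino-1,3,4-thiadiazol-2-yl in place of 5-methyl-1,3,4-oxadiazol-2-yl on a sulfur, with the step that the two limits leave unreadable from compound 2 to compound 3 likewise unreadable.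

Compound 4, `Nc1nnc(SCc2cc(=O)c3cc(Cl)ccc3o2)s1`, has not yet been measured in this assay. It differs from compound 3 by chloro in place of hydrogen on an aromatic carbon, the same change as from compound 2 to compound 1, made at the same place. Since compound 3 sits at the limit of > 25000 nM in this assay, at which 3 of the 3 values shown sit, and the earlier step of the same change stayed at that limit, the step that the limit leaves unreadable from compound 3 to compound 4 is expected to be small and most likely unreadable again. For compound 4 the estimate in this assay is therefore 30000 nM, spanning 12000 nM to 80000 nM.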

Compound 4, half-maximal inhibitory concentration: > 25000 nM
Compound 4: a limit, no number; the forecaster's own chance of this, stated with the estimate: 85%; the middle value is on the limit's open side.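

In this assay compound 4 gives > 25000 nM, which is a limit and not a number. Neither its step from compound 3 nor its step from compound 1 can be read, as every value shown stands at the same limit: the limit of > 25000 nM in this assay, at which 4 of the 4 values shown sit.

The compounds shown leave open whether chloro or 5-amino-1,3,4-thiadiazol-2-yl changes activity on this core at all.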